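Cyclopentyl versus cyclohexyl amides in a HEp-2 series

This account rests on a few compounds, and the source may have more. Where it says the series, first, only, none or still open, it means among the compounds named here.

Measured compounds:
compound 1, `CC(C)C(NC(=O)NO)C(=O)NC1CCCCC1`: in a functional assay on HEp-2 cells (Homo sapiens) for inhibition (on this read-out higher numbers stand for weaker inhibition and lower numbers for stronger inhibition), compound 1 gives > 100000 nM, a limit of the assay and not a number
compound 2, `CC(C)C(NC(=O)NO)C(=O)NC1CCCC1`: in this assay compound 2 gives 33400 nM
compound 3, `CC(C)C(NC(=O)n1nnc2ccccc21)C(=O)NC1CCCC1`: in this assay compound 3 gives 60300 nM

Compounds 1 and 2 share one core; compound 3 carries another, and the difference between the two cores is not broken down here. Compound 1 is set apart from compound 2 by cyclohexyl in place of cyclopentyl on an amide-type nitrogen. This change gives an at least 2.9-fold higher number from compound 2 to compound 1 (0.47 log units; beyond the scatter). Compound 1 sits at the limit of > 100000 nM in this assay, at which 1 of the 3 values shown sits. In this assay compound 3 stands nearest to compound 2, the two being within the usual scatter.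

Compound 4, `CC(C)C(NC(=O)n1nnc2ccccc21)C(=O)NC1CCCCC1`, is not yet measured. It differs from compound 3 by cyclohexyl in place of cyclopentyl on an amide-type nitrogen, the same change at the same place as that between compound 2 and compound 1. In this assay the step is expected to be a 2.8-fold higher number from compound 3 to compound 4 (0.45 log units; beyond the scatter), resting on an at least 2.9-fold higher number from compound 2 to compound 1 (0.47 log units; beyond the scatter). Compound 4 is therefore estimated at 170000 nM, expected between 60000 nM and 500000 nM, with a fair chance that only a limit is reported.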

Compound 4, half-maximal inhibitory concentration: 60000 nM
Compound 4: the middle estimate sits 2.8-fold (0.45 log units) above what was measured, within the range that was stated.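

In this assay, cyclohexyl in place of cyclopentyl on an amide-type nitrogen gives a 1.0-fold lower number from compound 3 to compound 4 (0.00 log units; within the scatter), so the change does not carry over unchanged from one core to the other: the same change on two cores in this assay, an at least 2.9-fold higher number (0.47 log units; beyond the scatter) from compound 2 to compound 1 and a 1.0-fold lower number (0.00 log units; within the scatter) from compound 3 to compound 4, at least 3.0-fold (0.47 log units) apart, beyond the scatter of two such steps. Compound 1 gives > 100000 nM, which is a limit of the assay and not a number, so the full size of the earlier step cannot be read: the limit of > 100000 nM in this assay, at which 1 of the 4 values shown sits. For these two pairs the outcome of the change depends on the core, but the data do not show which feature of either core is responsible, and two pairs set no rule for the wider series.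

The compounds shown leave open how cyclobutyl or cycloheptyl would behave on the same amide-type nitrogen on either core. They also leave open whether an open chain such as n-pentyl, or a cyclohexyl ring carrying an amine or a carboxylic acid, would give the same result on both cores.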